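The compounds below may be only part of what the source reports. "The series", "measured", "known", "first", "only" and "open" are said of these compounds alone.

Series notes. Compound 1 `Brc1ccc(-c2cc3ccccc3[nH]2)cc1` is the reference point for this step. In an assay on isolated protein for inhibition of Aromatase (Homo sapiens), read by fluorescence, using NADPH, with a stated time of 30 min, tested at 50 uM (on this read-out higher numbers stand for more inhibition at the one concentration tested (going by the name of the read-out) and lower numbers for less inhibition), compound 1 gives 4.8%, the lowest of the three numbers recorded so far. Compound 3 `COCn1c(-c2ccccc2)cc2ccccc21` gives 20.2% in this assay, the nearest number to that of compound 1, and the gap between the two lies beyond the usual scatter. Compound 2 `Nc1ccc2[nH]c(-c3ccccc3)cc2c1` gives 41.4% in this assay, the furthest from compound 1, and that gap also lies beyond the scatter. For the measured compounds named here, no pair of the measured compounds differs in just one place, so there is no single measured step to lean on.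

Compound 4 `FC(F)(F)Oc1ccc(-c2cc3ccccc3[nH]2)cc1` is not yet measured. It differs from compound 1 in one place: trifluoromethoxy in place of bromo on an aromatic carbon. Going by the values given here, nothing among the measured compounds shows what this kind of change does in this assay, since the three measured compounds differ from one another in several places at once. The expected step is a number 7.2 percentage points higher from compound 1 to compound 4 (within the scatter), small and most likely none beyond the scatter, with a modest rise as the more probable direction if there is any. Compound 4 is accordingly estimated to give 12% in this assay, with an expected range from 0% to 30%.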

Compound 4, a percentage reported as inhibition, at one concentration (the size of the read-out at that concentration, not a potency): 1.86%
Beside the measured number, compound 4's estimate is 10.1 percentage points above it; measured number inside the range.
By their numbers in this assay, from the lowest: compounds 4 and 1 (each within the scatter of the next); then compound 3; then compound 2.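

For the compounds shown here, the first single-place comparison falls at this aromatic carbon: in this assay, trifluoromethoxy in place of bromo gives a number 2.9 percentage points lower from compound 1 to compound 4 (within the scatter). The group entering brings more heavy atoms and a hydrogen-bond acceptor, yet the read-out stays within the scatter, so this exchange gives no measurable separation between compound 1 and compound 4 at the one concentration tested. Nothing available explains this result, and no cause can be assigned to it.

The compounds shown leave open whether any group at this place can move the number beyond the scatter, since only bromo and trifluoromethoxy have been compared here, and a carboxylic acid or a longer alkyl chain on the same aromatic carbon would test that more widely. They also leave open how the larger numbers of compound 2 and compound 3 arise, as each differs from the others in several places at once and neither can be traced to a single change.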